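This account rests on a few compounds, and the source may have more. Where it says the series, first, only, none or still open, it means among the compounds named here.

Four compounds sharing one core are compared in a functional assay on Huh-7 cells (Homo sapiens) for inhibition, read by MTT assay, with a stated time of 48 h; a higher number here means a weaker inhibitor, a lower number a stronger inhibitor. Compound 1 `COc1ccc2c(=O)c(/C=C/C(=O)Nc3ccc(C)cc3)coc2c1` gives in this assay > 100000 nM, which is a limit of the assay rather than a number (the limit of > 100000 nM in this assay, at which 1 of the 3 values shown sits). Compound 2 `COc1ccc2c(=O)c(/C=C/C(=O)Nc3ccc(Cl)cc3)coc2c1` gives in this assay 37100 nM. Going by the values given here, compound 3 `COc1ccc(CNC(=O)/C=C/c2coc3cc(OC)ccc3c2=O)cc1` gives in this assay 7570 nM, the lowest of the two numbers known so far, with compound 2 the nearest. Compound 4 `CCOc1ccc(NC(=O)/C=C/c2coc3cc(OC)ccc3c2=O)cc1` has not yet been measured. It differs from compound 3 only at the amide-type nitrogen: 4-ethoxyphenyl in place of 4-methoxybenzyl on an amide-type nitrogen. Compound 4 thus carries a substituted phenyl on that nitrogen, as compounds 1 and 2 do, whereas compound 3 carries 4-methoxybenzyl. The measured steps that bear on this change are an at least 13-fold lower number from compound 1 to compound 3 (1.12 log units; beyond the scatter) and a 4.9-fold lower number from compound 2 to compound 3 (0.69 log units; beyond the scatter), both of which paired the move to 4-methoxybenzyl with a clearly lower number. Reversing that move in compound 4 is therefore expected to raise the number, by about a 4.0-fold higher number from compound 3 to compound 4 (0.60 log units; beyond the scatter). Compound 4 is estimated at 30000 nM, within a range from 8000 nM to 150000 nM.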

Compound 4, half-maximal inhibitory concentration: 3230 nM
For compound 4 the middle estimate is 9.3-fold (0.97 log units) above the measured one; measured number below the stated range.
By their numbers in this assay, from the lowest: compound 4; then compound 3; then compound 2. At a limit, above all of these: compound 1.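

In this assay, 4-ethoxyphenyl in place of 4-methoxybenzyl on the amide-type nitrogen gives a 2.3-fold lower number from compound 3 to compound 4 (0.37 log units; beyond the scatter), so a substituted phenyl on that nitrogen does not by itself bring a higher number, and the earlier advantage of 4-methoxybenzyl held only against compounds 1 and 2. What the phenyl carries also counts: ethoxy in place of chloro gives an 11-fold lower number from compound 2 to compound 4 (1.06 log units; beyond the scatter), and ethoxy in place of methyl gives an at least 30-fold lower number from compound 1 to compound 4 (1.49 log units; beyond the scatter). That last step starts from a limit, the one for compound 1, and not from a number: the limit of > 100000 nM in this assay, at which 1 of the 4 values shown sits.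

As far as these compounds go, it remains open whether 4-methoxyphenyl, or a longer chain such as butoxy in place of ethoxy, would lower the number further. From the compounds shown here alone, it is equally open how an amine or a carboxylic acid on that phenyl would compare.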